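Carboxyphenyl variation: from compound 3 to compound 4

The source may hold more compounds than are shown below. What is called first, only, known or untested is meant among the compounds shown, and "the series" means these compounds.

Within the data shown here, compound 3 `Cc1c(OCCCCOc2ccc(C(=O)O)cc2F)ccc(C(=O)CC2CCCC2)c1O` gives 31.2% in an assay on HEK293 cells for positive allosteric modulation of metabotropic glutamate receptor 3 (Rattus norvegicus), read by thallium flux, with a stated time of 2.5 min (on this read-out lower numbers stand for smaller maximal responses and higher numbers for larger maximal responses), and stands second highest of the three numbers measured so far: nearest is compound 1 `Cc1c(OCCCCOc2ccc(C(=O)O)cc2Cl)ccc(C(=O)CC2CCCC2)c1O` with 27.4%, a gap within the scatter, and furthest is compound 2 `COc1ccc(C(=O)O)cc1OCCCCOc1ccc(C(=O)CC2CCCC2)c(O)c1C` with 67.6%, beyond it. Compound 4 `Cc1c(OCCCCOc2cccc(C(=O)O)c2)ccc(C(=O)CC2CCCC2)c1O` differs from compound 3 by 3-carboxyphenyl in place of 4-carboxy-2-fluorophenyl on an oxygen on a saturated carbon. The two steps that rework the carboxyphenyl ether were large, a number 40.2 percentage points higher from compound 1 to compound 2 (beyond the scatter) and a number 36.4 percentage points lower from compound 2 to compound 3 (beyond the scatter), whereas the halogen swap a number 3.8 percentage points higher from compound 1 to compound 3 (within the scatter) stayed within the scatter. Among the measured compounds shown here, removing the fluoro alone is therefore expected to matter little, but the move of the carboxy group has no measured counterpart, so a step in either direction remains possible. Compound 4 is expected to give 35%, with a range of 18% to 55%. For compound 4 the expected step is a number 3.8 percentage points higher from compound 3 to compound 4 (within the scatter).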

Compound 4, largest response reached (reported as percent of maximum), in percent of the reference or control that the assay uses: 92.9%
Estimate against measurement, compound 4: 57.9 percentage points below, and the stated range ends below it.
By their numbers in this assay, from the lowest: compounds 1 and 3 (each within the scatter of the next); then compound 2; then compound 4.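

In this assay, 3-carboxyphenyl on this oxygen stands far above both halogenated carboxyphenyl groups (a number 61.7 percentage points higher from compound 3 to compound 4 (beyond the scatter); a number 65.5 percentage points higher from compound 1 to compound 4 (beyond the scatter)), so this change, unlike the chloro-to-fluoro swap, moves the response strongly. Compound 2 already carries its carboxy group in the same placement, and hydrogen in place of methoxy still adds to the response (a number 25.3 percentage points higher from compound 2 to compound 4 (beyond the scatter)). The compounds shown do not separate the move of the carboxy group from the loss of the halogen, and whether a tetrazole or an amide could replace the carboxylic acid stays open. No evidence is available to explain the rise.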